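A few compounds are considered here, and "the series" means these few. Any claim that something is new, unique, unknown or untested is made for them only; others in the source may bear on it.

Compound 1 `CN(C)c1ccc(/C=N/C2=C(C#N)C(c3ccc(Cl)cc3Cl)C3=C(CCCC3=O)N2c2ccc(S(N)(=O)=O)cc2)cc1` was tested in a functional assay on Ehrlich cells (Mus musculus) for cytotoxicity, read by trypan blue exclusion, with a stated time of 2 h; on this read-out lower numbers stand for stronger inhibition and higher numbers for weaker inhibition; compound 1 returned only a limit, > 100 ug/mL. Compound 2 `CN(C)c1ccc(/C=C/C=N/C2=C(C#N)C(c3ccc(Cl)cc3Cl)C3=C(CCCC3=O)N2c2ccc(S(N)(=O)=O)cc2)cc1` likewise returned only a limit in this assay, > 100 ug/mL. The step that the two limits leave unreadable from compound 1 to compound 2 cannot be sized, since both values sit at the limit of > 100 ug/mL in this assay, at which 2 of the 2 values shown sit. Compound 3 `N#CC1=C(/N=C/c2ccc([N+](=O)[O-])cc2[N+](=O)[O-])N(c2ccc(S(N)(=O)=O)cc2)C2=C(C(=O)CCC2)C1c1ccc(Cl)cc1Cl` differs from compound 2 by 2,4-dinitrophenyl in place of 2-(4-(dimethylamino)phenyl)ethenyl on a carbon with a double bond to nitrogen. No measured step bears readably on this change, so no size of step in this assay can be expected in either direction from the numbers shown. Compound 3 is therefore expected to give 100 ug/mL (range 50 ug/mL to 200 ug/mL). The expected step of a number no higher from compound 2 to compound 3 (the limit leaves the size open) is an estimate only.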

Compound 3, half-maximal inhibitory concentration: > 100 ug/mL
Compound 3: a limit, no number; the forecaster's own chance of this, stated with the estimate: 80%; the middle value sits exactly at the limit.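

Compound 3 gives no readable step from compound 1 or compound 2 in this assay, because all three compounds return only a limit: the limit of > 100 ug/mL in this assay, at which 3 of the 3 values shown sit.

The compounds shown leave open whether any of these groups on a carbon with a double bond to nitrogen shifts the half-maximal inhibitory concentration.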